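Swapping a basic side chain for an amide in a CXCR4 series

The compounds below may be only part of what the source reports. "The series", "measured", "known", "first", "only" and "open" are said of these compounds alone.

Of the compounds shown here, three sharing one core have been measured in a functional assay on CEM-CCRF cells for antagonist activity at C-X-C chemokine receptor type 4 (Homo sapiens), read by calcium flux; a higher number here means a weaker inhibitor, a lower number a stronger inhibitor. Compound 1 `NCC#CCN(Cc1nc2ccccc2[nH]1)C1CCCc2cccnc21` gives 973 nM, and compound 2 `NCCN(Cc1nc2ccccc2[nH]1)C1CCCc2cccnc21` gives 1370 nM; the step of a 1.4-fold higher number from compound 1 to compound 2 (0.15 log units; within the scatter) is small. Compound 3 `CN(C)CCCCN(Cc1nc2ccccc2[nH]1)C1CCCc2cccnc21` gives 87 nM, the lowest of the three numbers, with the steps of an 11-fold lower number from compound 1 to compound 3 (1.05 log units; beyond the scatter) and a 16-fold lower number from compound 2 to compound 3 (1.20 log units; beyond the scatter) both large and both beyond the scatter. Compound 4 `NCCCC(=O)N(Cc1nc2ccccc2[nH]1)C1CCCc2cccnc21` has not yet been measured. The change is (3-aminopropyl)carbonyl in place of 4-(dimethylamino)butyl on an amine nitrogen. For the measured compounds named here, two measured steps bear on this: compounds 1 and 2, which carry a chain ending in a plain amino group, sit far above compound 3, whose chain ends in a dimethylamino group. Going by the values given here, compound 4 returns to a plain amino end and adds a carbonyl on the amine nitrogen, a change none of the measured pairs covers. A large rise in this assay is therefore expected, giving a 34-fold higher number from compound 3 to compound 4 (1.54 log units; beyond the scatter). Compound 4 is estimated at 3000 nM, within a range from 700 nM to 15000 nM.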

Compound 4, half-maximal inhibitory concentration: 3200 nM
For compound 4 the middle estimate is 1.1-fold (0.03 log units) below the measured one, and the stated range covers the measured number.
By their numbers in this assay, from the lowest: compound 3; then compounds 1 and 2 (each within the scatter of the next); then compound 4.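

In this assay, for the compounds shown here, a carbonyl on the amine nitrogen appears for the first time in compound 4, and the step from the dimethylamino chain is large, with a 37-fold higher number from compound 3 to compound 4 (1.57 log units; beyond the scatter) on record. Against the two chains that also end in a plain amino group the steps are only modest, with a 2.3-fold higher number from compound 2 to compound 4 (0.37 log units; beyond the scatter) and a 3.3-fold higher number from compound 1 to compound 4 (0.52 log units; beyond the scatter) on record, so most of the distance from compound 3 is already present in those chains, yet compound 4 still lies beyond the scatter of both. Nothing available here gives a cause for these steps.

As far as these compounds go, compound 4 changes the chain end and adds the carbonyl at once, so the share of each stays unknown. A 4-aminobutyl chain or a 4-(dimethylamino)butanoyl group on the same amine nitrogen would separate the two.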